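Methoxy for fluoro on the pendant phenyl ring

The source may report more compounds than this note shows. Statements on the series, on what has been measured and on what is new or still open speak of the compounds shown alone.

The series shares one amide core, varied so far only on the aromatic ring that carries the chloro, methoxy or methyl group. In a functional assay on A549 cells (Homo sapiens) for cytotoxicity, read by MTT assay, with a stated time of 72 h (a lower number here means a stronger inhibitor, a higher number a weaker inhibitor), compound 1 `O=C(Nc1nc2ccc(Cl)cc2s1)c1cn(-c2ccccc2)nc1-c1ccc(F)cc1` gives 3870 nM. Compound 3 `Cc1ccc2nc(NC(=O)c3cn(-c4ccccc4)nc3-c3ccc(F)cc3)sc2c1` gives 24600 nM in this assay. Compound 2 `COc1ccc2nc(NC(=O)c3cn(-c4ccccc4)nc3-c3ccc(F)cc3)sc2c1` reaches only the limit of this assay, > 50000 nM, so its true value is not known and it sits at the limit of > 50000 nM in this assay, at which 1 of the 3 values shown sits. Among the measured compounds the steps run an at least 12-fold higher number from compound 1 to compound 2 (1.11 log units; beyond the scatter) and a 6.4-fold higher number from compound 1 to compound 3 (0.80 log units; beyond the scatter), while an at least 2.0-fold lower number from compound 2 to compound 3 (0.30 log units; that floor lies within the scatter) cannot be separated from the scatter.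

Compound 4 `COc1ccc(-c2nn(-c3ccccc3)cc2C(=O)Nc2nc3ccc(OC)cc3s2)cc1` differs from compound 2 elsewhere: methoxy in place of fluoro on an aromatic carbon. For the measured compounds named here, none of the measured steps touches this ring, so they give no direct guide to the direction or size of this change; all three concern the other aromatic ring. Compound 2 starts at the limit of this assay. Compound 4 is therefore expected to show a step that the limit leaves unreadable from compound 2 to compound 4, that is, none beyond the scatter, and most likely to remain at the limit as well. The estimate for compound 4 in this assay is 60000 nM, with a range from 20000 nM to 200000 nM.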

Compound 4, half-maximal inhibitory concentration: 18900 nM
For compound 4 the middle estimate is 3.2-fold (0.50 log units) above the measured one; measured number outside the range, below it.
By their numbers in this assay, from the lowest: compound 1; then compounds 4 and 3 (each within the scatter of the next). At a limit, above all of these: compound 2.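

For the compounds shown here, the change from 4-fluorophenyl to 4-methoxyphenyl is the first reading at this position, para to a large group, and in this assay it gives an at least 2.6-fold lower number from compound 2 to compound 4 (0.42 log units; beyond the scatter). So the group on this ring does bear on the number, which the earlier compounds could not show, as all their differences lay on the other aromatic ring. Methoxy also does not act in one direction across the two rings: entering the other ring in place of chloro, it gave an at least 12-fold higher number from compound 1 to compound 2 (1.11 log units; beyond the scatter), whereas here it goes with a lower number, although the group it replaces differs. The true size of the new step stays unknown, and its figure is only a floor, because compound 2 stands at a limit: the limit of > 50000 nM in this assay, at which 1 of the 4 values shown sits.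

Going by these compounds, this rests on a single pair, so it remains open whether 4-methoxyphenyl would lower the number in the same way on compound 1, which carries chloro on the other ring, or on compound 3, which carries methyl there. Also open, on these data alone, is how an amine, a hydroxyl or a longer ether chain such as ethoxy would read at this position.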